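Amino in place of hydrogen on the phenyl series

The source may hold more compounds than are shown below. What is called first, only, known or untested is meant among the compounds shown, and "the series" means these compounds.

Going by the values given here, in a functional assay on cells (Homo sapiens) for antiproliferative activity, read by sulforhodamine B assay, with a stated time of 48 h (on this read-out higher numbers stand for weaker inhibition and lower numbers for stronger inhibition), compound 2 `CCCCCCCCCCCCCCCCNC(=O)[C@@H]1CSC(c2ccccc2)N1` gives 1900 nM and stands level, within the scatter, with its only measured neighbour. That neighbour, compound 1 `CCCCCCCCCCCCCCCCNC(=O)[C@@H]1CSC(c2ccc(NC(C)=O)cc2)N1`, gives 2100 nM and carries acetamido where compound 2 carries hydrogen.

Compound 3 `CCCCCCCCCCCCCCCCNC(=O)[C@@H]1CSC(c2ccc(N)cc2)N1` is not yet measured and comes from compound 2 by one change, amino in place of hydrogen on an aromatic carbon, para to a large group, counted as amino in place of hydrogen on an aromatic carbon in full. Among the compounds with values here, the only measured step at that place is a 1.1-fold lower number from compound 1 to compound 2 (0.04 log units; within the scatter) and it stays within the scatter. Within the data shown here, no compound with amino has a value yet, so this evidence is indirect. Among the measured compounds shown here, with that step as the sole guide, no shift beyond the scatter and no preferred direction is expected in this assay and the estimated step is a 1.1-fold lower number from compound 2 to compound 3 (0.02 log units; within the scatter) at this stage. For compound 3 the estimate is 1800 nM with an expected range from 800 nM to 4000 nM for now.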

Compound 3, half-maximal inhibitory concentration: 2300 nM
Compound 3: middle estimate off by 1.3-fold (0.11 log units), on the low side; measured number inside the range.
By their numbers in this assay, from the lowest: compounds 2, 1 and 3 (each within the scatter of the next).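

At the aromatic carbon para to a large group, amino now has its own value in this assay, with a 1.2-fold higher number from compound 2 to compound 3 (0.08 log units; within the scatter), so amino and hydrogen cannot be told apart at this position. The second new comparison, hydrogen in place of acetyl on the nitrogen on the aromatic ring, gives a 1.1-fold higher number from compound 1 to compound 3 (0.04 log units; within the scatter), so the free amino and acetamido also stand level, and all three groups lie within the scatter of one another. No supporting evidence accompanies this result.

The compounds shown leave open whether a different group at this position, such as a carboxylic acid, a nitrile or trifluoromethyl, would move the number beyond the scatter. They also leave open whether this flat picture would hold with a shorter chain on the amide nitrogen.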